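A few compounds are considered here, and "the series" means these few. Any claim that something is new, unique, unknown or untested is made for them only; others in the source may bear on it.

Working notes on the series. Compound 1 `COc1cc2ncnc(N3CCc4ccccc43)c2cc1NC(=O)/C=C/CN1CCN(C)CC1` and compound 2 `CN1CCN(C/C=C/C(=O)Nc2cc3c(N4CCc5ccccc54)ncnc3cc2O[C@@H]2CCOC2)CC1` share one core and differ in a single place: oxolan-3-yl in place of methyl on an oxygen on an aromatic ring. Compound 3 `COc1cc2ncnc(N3CCCc4ccccc43)c2cc1NC(=O)/C=C/CN(C)C` is built on a second core; the difference between the two cores is not broken down here. In a functional assay on MCF7 cells (Homo sapiens) for antiproliferative activity, read by MTT assay, with a stated time of 72 h (a lower number here means a stronger inhibitor, a higher number a weaker inhibitor), compound 1 gives 6430 nM and compound 2 gives 5350 nM, so the exchange produced a 1.2-fold lower number from compound 1 to compound 2 (0.08 log units; within the scatter). In this assay compound 3 gives 1770 nM, the lowest of the three numbers, with its steps to compound 2 and to compound 1 both beyond the scatter.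

Compound 4 `CN(C)C/C=C/C(=O)Nc1cc2c(N3CCCc4ccccc43)ncnc2cc1O[C@@H]1CCOC1` is not yet measured. It differs from compound 3 in one place, (oxolan-3-yl in place of methyl on an oxygen on an aromatic ring), the same change as from compound 1 to compound 2, and this change occurs only twice among the compounds shown. For compound 4 in this assay the step is expected to be a 1.2-fold lower number from compound 3 to compound 4 (0.07 log units; within the scatter), resting on the single earlier case, because that case gave a 1.2-fold lower number from compound 1 to compound 2 (0.08 log units; within the scatter). On that basis compound 4 is estimated at 1500 nM in this assay, with the likely range from 700 nM to 3500 nM.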

Compound 4, half-maximal inhibitory concentration: 2850 nM
Estimate against measurement, compound 4: 1.9-fold (0.28 log units) below; measured number inside the range.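

In this assay the exchange of methyl for oxolan-3-yl on an oxygen on an aromatic ring gave a 1.6-fold higher number from compound 3 to compound 4 (0.21 log units; within the scatter), so compound 3 and compound 4 cannot be told apart, just as compound 1 and compound 2 cannot. The two cases do not differ from each other: the same change on two cores in this assay, a 1.2-fold lower number (0.08 log units; within the scatter) from compound 1 to compound 2 and a 1.6-fold higher number (0.21 log units; within the scatter) from compound 3 to compound 4, 1.9-fold (0.29 log units) apart, within the scatter of two such steps. This shows that in these two pairs the change carries from one core to the other with no step beyond the scatter, but two pairs in a single assay do not show that it would stay neutral on any further core, and they do not show what the change does outside this assay.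

The compounds shown leave open whether a different group on that oxygen, such as a longer chain ending in an amine or one ending in a carboxylic acid, would give a step beyond the scatter. They also leave open how the mirror-image form of the oxolan-3-yl group would compare on either core.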